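The source may hold more compounds than are shown below. What is called first, only, known or untested is meant among the compounds shown, and "the series" means these compounds.

Working notes on the series.

Three compounds share one core and differ at a single aromatic carbon. Compound 1 `CC(C(=O)NCc1ccc(C(F)(F)F)nc1NCc1ccc(Cl)cc1)c1ccc(NS(C)(=O)=O)c(F)c1` gives 414 nM in a functional assay on CHO-K1 cells for antagonist activity at transient receptor potential cation channel subfamily V member 1 (Homo sapiens), read by FLIPR; a higher number here means a weaker inhibitor, a lower number a stronger inhibitor. For the measured compounds named here, compound 3 `CC(C(=O)NCc1ccc(C(F)(F)F)nc1N(C)c1ccccc1)c1ccc(NS(C)(=O)=O)c(F)c1` gives 57.4 nM in this assay, and the step of a 7.2-fold lower number from compound 1 to compound 3 (0.86 log units; beyond the scatter) is the only measured step in the set. Compound 2 `CC(C(=O)NCc1ccc(C(F)(F)F)nc1NCc1cccnc1)c1ccc(NS(C)(=O)=O)c(F)c1` is reported as "not active" (no number reported) in this assay, so no number is available; on the numbers shown, compound 2 stands apart from compound 1 and compound 3 simply as the compound without a measurable value.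

Compound 4 `CC(=O)OC1CCN(c2nc(C(F)(F)F)ccc2CNC(=O)C(C)c2ccc(NS(C)(=O)=O)c(F)c2)CC1` differs from compound 2 by 4-acetoxypiperidin-1-yl in place of ((pyridin-3-yl)methyl)amino on an aromatic carbon. Going by the values given here, no measured step joins compound 2 or compound 4 to another compound, and the step from compound 1 to compound 3 concerns a different pair of groups at the same carbon, so it offers only a rough indication of the range this position can span. Among the compounds with values here, with compound 2 giving no number, the direction of the change to compound 4 in this assay cannot be stated; the expectation is only that compound 4 is estimated to fall near 400 nM, with a wide range from 60 nM to 3000 nM, and with a real chance that the assay again reports no number.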

Compound 4, half-maximal inhibitory concentration: 139 nM
Estimate against measurement, compound 4: 2.9-fold (0.46 log units) above; the measured number falls inside the stated range.
By their numbers in this assay, from the lowest: compound 3; then compound 4; then compound 1.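

With 4-acetoxypiperidin-1-yl on this carbon, compound 4 gives a number in this assay, so a group with a non-aromatic ring and no aromatic ring can still give a measurable value here, although the step from compound 2 cannot be read without a number for compound 2. The new group places compound 4 between the two earlier numbers, with a 2.4-fold higher number from compound 3 to compound 4 (0.38 log units; beyond the scatter) and a 3.0-fold lower number from compound 1 to compound 4 (0.47 log units; beyond the scatter), so methyl(phenyl)amino remains the best group shown at this carbon. No measurement shown accounts for these differences.

On these data alone, what the acetoxy part contributes remains open, and a plain piperidin-1-yl or a 4-hydroxypiperidin-1-yl at the same carbon would separate it from the ring. Whether a morpholin-4-yl ring would keep a measurable value is also unresolved.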